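The compounds below may be only part of what the source reports. "The series", "measured", "known", "first", "only" and "open" are said of these compounds alone.

Measured so far in an ADME assay on HT-29 cells (Homo sapiens) for inhibition, read by MTT assay, with a stated time of 72 h; a higher number here means a weaker inhibitor, a lower number a stronger inhibitor:
compound 1, `CN(C)C/C=C/C(=O)Nc1cccc(Nc2nc(N/N=C/c3ccccc3F)ncc2Cl)c1`: 3660 nM
compound 2, `CN(C)C/C=C/C(=O)Nc1cccc(Nc2nc(N/N=C/c3ccc(F)cc3F)ncc2Cl)c1`: 2920 nM
compound 3, `C/C(=N\Nc1ncc(Cl)c(Nc2cccc(NC(=O)/C=C/CN(C)C)c2)n1)c1ccc(F)cc1`: 10200 nM

Compound 3 gives the highest of the three numbers in this assay. The steps to it are a 2.8-fold higher number from compound 1 to compound 3 (0.45 log units; beyond the scatter) and a 3.5-fold higher number from compound 2 to compound 3 (0.54 log units; beyond the scatter), both beyond the scatter, so compound 3 is the weakest inhibitor of the three. Between compound 1 and compound 2 the step is a 1.3-fold lower number from compound 1 to compound 2 (0.10 log units; within the scatter), within the scatter.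

Compound 4, `C/C(=N\Nc1ncc(Cl)c(Nc2cccc(NC(=O)/C=C/CN(C)C)c2)n1)c1cccnc1`, has not yet been measured. It differs from compound 3 in one place: pyridin-3-yl in place of 4-fluorophenyl on a carbon with a double bond to nitrogen

Within the data shown here, no measured step exchanges the aromatic ring on that carbon for a different ring. The closest guide is a 1.3-fold lower number from compound 1 to compound 2 (0.10 log units; within the scatter), a change on that same ring which stayed within the scatter. The steps of a 2.8-fold higher number from compound 1 to compound 3 (0.45 log units; beyond the scatter) and a 3.5-fold higher number from compound 2 to compound 3 (0.54 log units; beyond the scatter) exchange a larger group that contains the ring together with the carbon bearing it, and do not separate the ring from the rest. On this basis no step beyond the scatter is expected for compound 4 in this assay, and the expected step is a 1.1-fold lower number from compound 3 to compound 4 (0.05 log units; within the scatter). Compound 4 is estimated at 9000 nM, with a range from 4000 nM to 22000 nM.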

Compound 4, half-maximal inhibitory concentration: 9660 nM
For compound 4 the middle estimate is 1.1-fold (0.03 log units) below the measured one; measured number inside the range.
By their numbers in this assay, from the lowest: compounds 2 and 1 (each within the scatter of the next); then compounds 4 and 3 (each within the scatter of the next).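

In this assay, among these compounds, the ring on the carbon with a double bond to nitrogen is exchanged for the first time on its own, pyridin-3-yl in place of 4-fluorophenyl, and this gives a 1.1-fold lower number from compound 3 to compound 4 (0.02 log units; within the scatter). At this position, then, a six-membered aromatic ring of carbon only carrying fluorine and a six-membered aromatic ring with 1 hetero atom and 1 hydrogen-bond acceptor are not told apart by this assay, at least in this one pair. Compound 4 stays separated from the two compounds with a hydrogen on that carbon, with a 2.6-fold higher number from compound 1 to compound 4 (0.42 log units; beyond the scatter) and a 3.3-fold higher number from compound 2 to compound 4 (0.52 log units; beyond the scatter), both beyond the scatter, yet no measurement accompanying these numbers bears on what lies behind either the flat ring exchange or this separation.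

Those two steps change the ring and the saturated chain carbon together, so the share of each remains unresolved. Also open, on these data alone, is whether the flat response holds for a thienyl ring, a phenyl ring carrying a carboxylic acid or an amine, or an ethyl chain in place of the saturated chain carbon.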